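The source may hold more compounds than are shown below. What is called first, only, known or untested is meant among the compounds shown, and "the series" means these compounds.

For the measured compounds named here, compound 2 `OC[C@H]1O[C@@H](n2cnc3c(NCc4ccc(Br)cc4)ncnc32)[C@H](O)[C@@H]1O` gives 68200 nM in a functional assay on K562 cells (Homo sapiens) for antiproliferative activity, with a stated time of 72 h (on this read-out lower numbers stand for stronger inhibition and higher numbers for weaker inhibition), the higher of the two numbers so far, though compound 1 `OC[C@H]1O[C@@H](n2cnc3c(NCc4ccccc4Cl)ncnc32)[C@H](O)[C@@H]1O` at 64000 nM lies within the scatter of it. Compound 3 `OC[C@H]1O[C@@H](n2cnc3c(NCc4ccc(Cl)cc4Cl)ncnc32)[C@H](O)[C@@H]1O` differs from compound 2 by 2,4-dichlorophenyl in place of 4-bromophenyl on a saturated chain carbon bound to a nitrogen on an aromatic ring. Going by the values given here, the one measured step that bears on this change is a 1.1-fold higher number from compound 1 to compound 2 (0.03 log units; within the scatter), which also exchanged the substituted phenyl on a saturated chain carbon bound to a nitrogen on an aromatic ring and stayed within the scatter. No step beyond the scatter is therefore expected here: a 1.0-fold lower number from compound 2 to compound 3 (0.02 log units; within the scatter). Compound 3 is thus estimated at 65000 nM, between 30000 nM and 140000 nM.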

Compound 3, half-maximal inhibitory concentration: 106000 nM
Compound 3: the middle estimate sits 1.6-fold (0.21 log units) below what was measured; measured number inside the range.
By their numbers in this assay, from the lowest: compounds 1, 2 and 3 (each within the scatter of the next).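

Putting 2,4-dichlorophenyl in place of 4-bromophenyl gives a 1.6-fold higher number from compound 2 to compound 3 (0.19 log units; within the scatter), and chloro in place of hydrogen on an aromatic carbon gives a 1.7-fold higher number from compound 1 to compound 3 (0.22 log units; within the scatter). In this assay, a phenyl carrying two halogens at this place therefore stays within the scatter of both phenyls carrying one, so the three compounds do not separate. Nothing available accounts for this result. From the compounds shown here alone, it remains open whether a phenyl bearing an amine or a carboxylic acid, or a longer chain to the ring, would move the number beyond the scatter.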